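The compounds below may be only part of what the source reports. "The series", "measured", "known", "first", "only" and "open" are said of these compounds alone.

Compound 1 `CCOc1ccc(Cl)cc1-c1ncc(C(=O)O)c(=O)[nH]1` and compound 2 `CCOC(=O)c1cnc(-c2cc(Cl)ccc2OCC)[nH]c1=O` share one core. In a functional assay on the whole organism (strain Sprague-Dawley) for inhibition, with Rattus norvegicus as the target, with a stated time of 10 min (on this read-out higher numbers stand for an effect only at larger amounts of compound and lower numbers for an effect already at smaller amounts), compound 1 gives 0.5 mg/kg and compound 2 gives 0.5 mg/kg, so that no change at the digits printed from compound 1 to compound 2 (within the scatter) stays within the scatter; compound 2 stands level with compound 1 at the digits shown. Compound 3 `CCOC(=O)c1cnc(-c2cc(N)ccc2OCC)[nH]c1=O` carries amino in place of chloro on an aromatic carbon. Among the compounds with values here, no measured step exchanges a chloro for an amino, so the only known step offers no guide to this one. A step of a 2.0-fold higher number from compound 2 to compound 3 (0.30 log units; within the scatter) is therefore expected, with wide uncertainty. Compound 3 is estimated at 1 mg/kg, within a range from 0.25 mg/kg to 4 mg/kg.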

Compound 3, dose for 50% inhibition: 0.5 mg/kg
For compound 3 the middle estimate is 2.0-fold (0.30 log units) above the measured one; the measured number falls inside the stated range.
By their numbers in this assay, from the lowest: compounds 1, 2 and 3 (each within the scatter of the next).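

In this assay, amino in place of chloro on the aromatic carbon para to an ethoxy group gives no change at the digits printed from compound 2 to compound 3 (within the scatter) and so leaves the read-out level. Within the data shown here, the earlier step changed only the ethyl on the oxygen next to a carbonyl group, so this is the first sign that this aromatic carbon also accepts a change, even to a group counted as a hydrogen-bond donor and acceptor. Nothing available explains this flat result.

Going by these compounds, whether a larger group here, such as an acetamide or a carboxylic acid, would stay level remains open. So does whether amino would behave the same alongside the free acid of compound 1.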